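Swapping the sulfonamide amine from dimethylamino to pyrrolidine

The source may report more compounds than this note shows. Statements on the series, on what has been measured and on what is new or still open speak of the compounds shown alone.

Compound 1 `CN1CCN(Cc2ccc(Nc3ncc(F)c(-c4ccc(F)cc4S(=O)(=O)N4CCCC4)n3)cc2)CC1`: 1150 nM
Compound 2 `CN1CCN(Cc2ccc(Nc3ncc(Cl)c(-c4ccc(F)cc4S(=O)(=O)N(C)C)n3)cc2)CC1`: 82 nM

In an assay on isolated protein for inhibition of tyrosine-protein kinase receptor UFO (Homo sapiens), read by TR-FRET, with a stated time of 60 min (on this read-out lower numbers stand for stronger inhibition and higher numbers for weaker inhibition), compound 2 gives the lower of the two numbers, and compound 1 sits at a higher value that lies beyond the usual scatter. The two compounds differ in two places at once, so neither change alone can be credited for the gap. Compound 3 `CN1CCN(Cc2ccc(Nc3ncc(Cl)c(-c4ccc(F)cc4S(=O)(=O)N4CCCC4)n3)cc2)CC1` keeps the core of compound 2 and changes only one place: pyrrolidin-1-yl in place of dimethylamino on a sulfonyl sulfur. Compound 1 already carries this pyrrolidinyl group, so a rise in the number is expected, but a moderate one. For compound 3 the estimated step of a 3.0-fold higher number from compound 2 to compound 3 (0.48 log units; beyond the scatter) leads to an expected value of 250 nM, with a range from 60 nM to 1000 nM.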

Compound 3, half-maximal inhibitory concentration: 91 nM
For compound 3 the middle estimate is 2.7-fold (0.44 log units) above the measured one; low and high end bracket the measured number.
By their numbers in this assay, from the lowest: compounds 2 and 3 (each within the scatter of the next); then compound 1.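

Within this assay the swap on the sulfonyl sulfur, pyrrolidin-1-yl in place of dimethylamino, gives a 1.1-fold higher number from compound 2 to compound 3 (0.05 log units; within the scatter) and so shows that this position accepts either group without a change beyond the scatter. Chloro in place of fluoro on an aromatic carbon gives a 13-fold lower number from compound 1 to compound 3 (1.10 log units; beyond the scatter) and so, of the two differences between compound 1 and compound 2, this one tracks the large gap. Nothing available explains either result. As far as these compounds go, whether morpholin-4-yl or diethylamino on the sulfonyl sulfur would give a similar number remains open, as does how bromo or methyl would compare with chloro on that aromatic carbon.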